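This account rests on a few compounds, and the source may have more. Where it says the series, first, only, none or still open, it means among the compounds named here.

Working notes on the series.

Three compounds of the shared core have a number in a functional assay on isolated protein for inhibition of Glucose-dependent insulinotropic receptor (Rattus norvegicus), read by HTRF and cAMP accumulation; a lower number here means that less compound is needed, a higher number that more compound is needed for the effect. Compound 1 `Cc1nc(S(C)(=O)=O)ccc1Oc1ncnc(OC2CCN(C(=O)OC(C)(C)C#N)CC2)c1F` gives 1320 nM. Compound 2 `Cc1nc(S(C)(=O)=O)ccc1Oc1ncnc(OC2CCN(C(=O)OC(C)(C)CF)CC2)c1F` gives 138 nM. Compound 3 `Cc1nc(S(C)(=O)=O)ccc1Oc1ncnc(OC2CCN(C(=O)O[C@@H](C)C(F)(F)F)CC2)c1F` gives 109 nM. Compound 2 therefore stands second highest of the three: its nearest neighbour is compound 3, at a 1.3-fold lower number from compound 2 to compound 3 (0.10 log units; within the scatter), a gap within the scatter, while compound 1 sits furthest away, with a 9.6-fold lower number from compound 1 to compound 2 (0.98 log units; beyond the scatter). The parallel step a 12-fold lower number from compound 1 to compound 3 (1.08 log units; beyond the scatter) shows the same thing: removing the nitrile from the carbon on the oxygen next to the carbonyl group pays off strongly, whereas swapping one fluorinated alkyl for another does little.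

Compound 4 `Cc1nc(S(C)(=O)=O)ccc1Oc1ncnc(OC2CCN(C(=O)C3CCCC3)CC2)c1F` is the next case. Relative to compound 2 the change is a group of 5 heavy atoms (5 carbon; one five-membered non-aromatic ring of carbon only) in place of a group of 6 heavy atoms (4 carbon, 1 oxygen, 1 fluorine; no ring), on a carbonyl carbon. Going by the values given here, none of the measured steps covers this: they all keep an oxygen on the carbonyl carbon and vary only what sits on it, and compound 4 removes that oxygen altogether. The measured steps show only that this region is sensitive, through a 9.6-fold lower number from compound 1 to compound 2 (0.98 log units; beyond the scatter), yet tolerant of shape, through a 1.3-fold lower number from compound 2 to compound 3 (0.10 log units; within the scatter). A cyclopentyl is expected to be accepted roughly like the fluorinated alkyls, but with wide uncertainty. For compound 4 the expected number in this assay is 300 nM, within 60 nM to 1500 nM, which would mean an estimated 2.2-fold higher number from compound 2 to compound 4 (0.34 log units; beyond the scatter).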

Compound 4, half-maximal effective concentration: 407 nM
Compound 4: the middle estimate sits 1.4-fold (0.13 log units) below what was measured; the measured number falls inside the stated range.
By their numbers in this assay, from the lowest: compounds 3 and 2 (each within the scatter of the next); then compound 4; then compound 1.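

In this assay, going by these compounds alone, compound 4 is the first case without an oxygen on the carbonyl carbon, and the change has a cost against both fluorinated groups: a 2.9-fold higher number from compound 2 to compound 4 (0.47 log units; beyond the scatter) and a 3.7-fold higher number from compound 3 to compound 4 (0.57 log units; beyond the scatter). The tolerance seen between compound 2 and compound 3 therefore does not extend fully to a cyclopentyl attached directly to the carbonyl carbon. Even so, that oxygen is not needed for a number better than that of the nitrile-bearing compound, as a 3.2-fold lower number from compound 1 to compound 4 (0.51 log units; beyond the scatter) shows, so the group carried on the carbonyl carbon matters here and not only the presence of the oxygen.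

No data at hand give a reason for these steps. The oxygen and the alkyl group change together in all three steps. Their contributions remain inseparable, and the compounds shown leave open whether a cyclopentyloxy group on the same carbonyl carbon would stand with compound 2 and compound 3 or nearer compound 4, and how a dimethylamino group there would compare.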